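Swapping an Aryl Group in a Microsomal Clearance Series

A few compounds are considered here, and "the series" means these few. Any claim that something is new, unique, unknown or untested is made for them only; others in the source may bear on it.

Compound 1 `CCn1cc(-c2cc(C(O)(C(F)(F)F)C(F)(F)F)cnc2N2CCN(S(=O)(=O)c3ccc(N)nc3)CC2)cn1` was tested in an ADME assay (liver) for metabolic stability, with Liver microsome (Rattus norvegicus) as the target, using microsomes and NADPH, with a stated time of 30 min, tested at 1 uM (a higher number here means faster removal of the compound, a lower number slower removal), where compound 1 gives 194 mL.min-1.g-1. Of the two numbers available this is the higher one; its nearest neighbour is compound 2 `Nc1ccc(S(=O)(=O)N2CCN(c3ncc(C(O)(C(F)(F)F)C(F)(F)F)cc3-c3ccccc3O)CC2)cn1`, which in this assay gives 125 mL.min-1.g-1, and the step of a 1.6-fold lower number from compound 1 to compound 2 (0.19 log units; within the scatter) is within the scatter. The unmeasured compound 3 `Nc1ccc(S(=O)(=O)N2CCN(c3ncc(C(O)(C(F)(F)F)C(F)(F)F)cc3-c3ccc4sccc4c3)CC2)cn1` differs from compound 1 at one place: 1-benzothiophen-5-yl in place of 1-ethyl-1H-pyrazol-4-yl on an aromatic carbon. Among the measured compounds shown here, only one measured step bears on this change, the replacement of the same 1-ethyl-1H-pyrazol-4-yl group by 2-hydroxyphenyl, which gave a 1.6-fold lower number from compound 1 to compound 2 (0.19 log units; within the scatter) and so did not move the number beyond the scatter. Compound 3 is therefore expected to show a step of a 1.2-fold higher number from compound 1 to compound 3 (0.07 log units; within the scatter) that stays within the scatter. On that basis the estimate for compound 3 in this assay is 230 mL.min-1.g-1, with a range from 100 mL.min-1.g-1 to 500 mL.min-1.g-1.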

Compound 3, intrinsic clearance in microsomes: 487 mL.min-1.g-1
Compound 3: middle estimate off by 2.1-fold (0.33 log units), on the low side; measured number inside the range.
By their numbers in this assay, from the lowest: compounds 2 and 1 (each within the scatter of the next); then compound 3.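

Among the compounds shown here, at this position, on an aromatic carbon two atoms from the ring nitrogen, the number in this assay does respond to the group placed there: 1-benzothiophen-5-yl gives a 2.5-fold higher number from compound 1 to compound 3 (0.40 log units; beyond the scatter) and is the first change here to pass beyond the scatter. Set against the 2-hydroxyphenyl group, the same change gives a 3.9-fold higher number from compound 2 to compound 3 (0.59 log units; beyond the scatter) and so places compound 3 apart from both compound 1 and compound 2, which remain within the scatter of each other. Nothing available here accounts for the rise.

The compounds shown leave open whether the higher number goes with the fused pair of rings or with the sulfur, which a 2-naphthyl or a 1-benzofuran-5-yl group at this place could separate. They also leave open where a plain phenyl group would fall.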